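Replacing the sulfonyl aryl group of compound 3

A few compounds are considered here, and "the series" means these few. Any claim that something is new, unique, unknown or untested is made for them only; others in the source may bear on it.

In a functional assay on CHO cells for inhibition of Orexin receptor type 2 (Homo sapiens), read by FLIPR and calcium flux (on this read-out lower numbers stand for stronger inhibition and higher numbers for weaker inhibition), compound 3 `CCN(CC)C(=O)CN(c1ccc(C)cc1)S(=O)(=O)c1cccc(C)c1` gives 60 nM, the lowest number among the three measured compounds. Compound 2 `CCN(CC)C(=O)CN(c1cc(N2CCCC2)ccc1Cl)S(=O)(=O)c1ccc(OC)c(OC)c1` gives 1610 nM, and compound 1 `CCN(CC)C(=O)CN(c1cc(N(CC)CC)ccc1Cl)S(=O)(=O)c1ccc(OC)c(OC)c1` gives 2410 nM; the step of a 1.5-fold lower number from compound 1 to compound 2 (0.18 log units; within the scatter) lies within the scatter. Compound 4 `CCN(CC)C(=O)CN(c1ccc(C)cc1)S(=O)(=O)c1ccc(Br)cc1` differs from compound 3 by the change (4-bromophenyl in place of 3-methylphenyl on a sulfonyl sulfur). Within the data shown here, no measured step touches the group on the sulfonyl sulfur: the only step on record concerns the aromatic amine of compound 1 and compound 2 and gives no guidance here. The estimate for compound 4 therefore rests on compound 3 alone, and the expected step of a 1.7-fold higher number from compound 3 to compound 4 (0.22 log units; within the scatter) is taken as small, in no firm direction. Compound 4 is estimated at 100 nM, with a range from 30 nM to 400 nM.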

Compound 4, half-maximal inhibitory concentration: 142 nM
Compound 4: middle estimate off by 1.4-fold (0.15 log units), on the low side, within the range that was stated.
By their numbers in this assay, from the lowest: compound 3; then compound 4; then compounds 2 and 1 (each within the scatter of the next).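

In this assay, the group on the sulfonyl sulfur now has a measured step of its own: 4-bromophenyl in place of 3-methylphenyl gives a 2.4-fold higher number from compound 3 to compound 4 (0.37 log units; beyond the scatter), a modest change. The number moves although both groups count the same heavy atoms and neither has a hydrogen-bond donor, hydrogen-bond acceptor or net charge. Nothing measured here accounts for the step.

The exchange alters both the substituent and its place on the ring, and these remain unseparated. A 4-methylphenyl or 3-bromophenyl group on the sulfonyl sulfur would tell them apart.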